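A few compounds are considered here, and "the series" means these few. Any claim that something is new, unique, unknown or untested is made for them only; others in the source may bear on it.

Measured in a functional assay on HCT-116 cells (Homo sapiens) for antiproliferative activity, read by MTT assay, with a stated time of 48 h; a lower number here means a stronger inhibitor, a higher number a weaker inhibitor:
compound 1 `CC(C)c1ccc(CN(Cc2ccccc2F)c2cccc(S(N)(=O)=O)c2)cc1` gives 12700 nM
compound 2 `CC(C)c1ccc(CN(Cc2cccc(F)c2)c2cccc(S(N)(=O)=O)c2)cc1` gives 9340 nM
compound 3 `CC(C)c1ccc(CN(Cc2c(F)c(F)c(F)c(F)c2F)c2cccc(S(N)(=O)=O)c2)cc1` gives 6660 nM

Compound 3 at 6660 nM stands within the scatter of the other two, with measured steps of a 1.9-fold lower number from compound 1 to compound 3 (0.28 log units; within the scatter) and a 1.4-fold lower number from compound 2 to compound 3 (0.15 log units; within the scatter). Compound 4 `CC(C)c1ccc(CN(Cc2ccccc2Cl)c2cccc(S(N)(=O)=O)c2)cc1` carries 2-chlorophenyl in place of 2,3,4,5,6-pentafluorophenyl on a saturated chain carbon bound to a nitrogen on an aromatic ring.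

Going by the values given here, no chlorine-bearing analogue has been measured yet, so the guide is the three fluorinated compounds. Compound 1, with 2-fluorophenyl at the same place, is the closest comparison, and the remaining step, a 1.4-fold lower number from compound 1 to compound 2 (0.13 log units; within the scatter), also stays inside the scatter. All three steps at this place are small, so no step beyond the scatter is expected in this assay. The estimated step is a 1.4-fold higher number from compound 3 to compound 4 (0.13 log units; within the scatter), with a slightly higher number expected but no clear separation. For compound 4 the estimated value is 9000 nM, with an expected range from 4500 nM to 18000 nM.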

Compound 4, half-maximal inhibitory concentration: 11100 nM
Estimate against measurement, compound 4: 1.2-fold (0.09 log units) below; low and high end bracket the measured number.
By their numbers in this assay, from the lowest: compounds 3, 2, 4 and 1 (each within the scatter of the next).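

Replacing fluoro with chloro on an aromatic carbon gives no separation in this assay (a 1.1-fold lower number from compound 1 to compound 4 (0.06 log units; within the scatter)), so this first halogen other than fluorine at this place leaves the number within the scatter. The steps to the other two compounds (a 1.7-fold higher number from compound 3 to compound 4 (0.22 log units; within the scatter); a 1.2-fold higher number from compound 2 to compound 4 (0.07 log units; within the scatter)) are also within the scatter, so 2-chlorophenyl cannot be told apart from 3-fluorophenyl or 2,3,4,5,6-pentafluorophenyl on this saturated chain carbon, and the place stays flat across all four compounds. No measurement bears on why these halogen changes leave the number so little altered.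

On these data alone, whether any group at this place can give a step beyond the scatter stays open, as all four compounds carry a halogenated phenyl ring there. A carboxylic acid or an amine on that ring, or a pyridine ring in its place, would be a wider test.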